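Furan to Thiophene on a Cyclohexyl Ester Dihydropyrimidinone

The source may hold more compounds than are shown below. What is called first, only, known or untested is meant among the compounds shown, and "the series" means these compounds.

Measured compounds:
Compound 1 `CCCOC(=O)C1=C(C)NC(=O)NC1c1cccs1` — 43%
Compound 2 `CC1=C(C(=O)OC2CCCCC2)C(c2ccco2)NC(=O)N1` — 1%

Of the compounds shown here, two have been measured in an assay on membranes from CHO cells for displacement of a labelled ligand from adenosine receptor A1 (Homo sapiens), read by scintillation counting, with a stated time of 60 min, tested at 1 uM; on this read-out lower numbers stand for less inhibition and higher numbers for more inhibition at the one concentration tested (going by the name of the read-out). Compound 1 `CCCOC(=O)C1=C(C)NC(=O)NC1c1cccs1` gives 43% in this assay. Compound 2 `CC1=C(C(=O)OC2CCCCC2)C(c2ccco2)NC(=O)N1` gives 1% in this assay, the lower of the two numbers, with compound 1 standing a good way higher, beyond the scatter. Among the compounds with values here, compound 1 and compound 2 differ in two places at once, so no single step between them can be read from the numbers.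

Compound 3 `CC1=C(C(=O)OC2CCCCC2)C(c2cccs2)NC(=O)N1` has not yet been measured in this assay. It differs from compound 2 in one place: thiophen-2-yl in place of furan-2-yl on a saturated ring carbon. Compound 1, which carries thiophen-2-yl, gives 43%, so the change is expected to move compound 3 upward, though the ester in compound 1 also differs and leaves the size uncertain. The estimated step of a number 14 percentage points higher from compound 2 to compound 3 (beyond the scatter) is expected to be modest. Compound 3 is estimated to give 15% in this assay, with a range from 0% to 40%.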

Compound 3, a percentage reported as inhibition, at one concentration (the size of the read-out at that concentration, not a potency): 7%
The estimate for compound 3 lay 8 percentage points above the measured number; the measured number falls inside the stated range.
By their numbers in this assay, from the lowest: compounds 2 and 3 (each within the scatter of the next); then compound 1.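

In this assay, thiophen-2-yl in place of furan-2-yl on a saturated ring carbon, with the cyclohexyl ester held constant, gives a number 6 percentage points higher from compound 2 to compound 3 (within the scatter), so on this ester the two five-membered aromatic rings cannot be told apart by this read-out. The same compound 3 also provides the first single-place comparison at the ester, where cyclohexyl in place of propyl on an oxygen next to a carbonyl group gives a number 36 percentage points lower from compound 1 to compound 3 (beyond the scatter), a large step, which makes the ester the only place among these compounds where a change beyond the scatter is seen, while thiophen-2-yl is not enough on its own to keep the number of compound 1 in this assay. Nothing measured here gives a reason for either step.

From the compounds shown here alone, whether furan-2-yl and thiophen-2-yl would also stay within the scatter of each other on the propyl ester remains open, since the flat numbers on the cyclohexyl ester may not carry over to a compound with a higher reading. Going by these compounds, it is also open how the number would move along the ester series, for instance with an ethyl group, a butyl chain or a benzyl group on that oxygen, or with a phenyl ring on the saturated ring carbon.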